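Swapping a Hydrogen for Pyridin-3-yl on an Oxazole Ketone

A few compounds are considered here, and "the series" means these few. Any claim that something is new, unique, unknown or untested is made for them only; others in the source may bear on it.

Compound 2 `CCCCCCCC/C=C\CCCCCCC(=O)c1ncco1` is one of three compounds tested in an assay on isolated protein for inhibition of Fatty-acid amide hydrolase 1 (Homo sapiens); a higher number here means a weaker inhibitor, a lower number a stronger inhibitor; compound 2 gives 17 nM. Compound 1 `CCCCCCCC/C=C\CCCCCCC(=O)c1ncc(-c2ccccn2)o1` gives 18 nM, and compound 3 `CCCCCCCC/C=C\CCCCCCC(=O)c1cccnn1` gives 130 nM. Compound 2 sits at the low end of these numbers: a 1.1-fold lower number from compound 1 to compound 2 (0.02 log units; within the scatter), while a 7.6-fold higher number from compound 2 to compound 3 (0.88 log units; beyond the scatter). Compound 4 `CCCCCCCC/C=C\CCCCCCC(=O)c1ncc(-c2cccnc2)o1` differs from compound 2 by pyridin-3-yl in place of hydrogen on an aromatic carbon. The step that bears on this is a 1.1-fold lower number from compound 1 to compound 2 (0.02 log units; within the scatter), which shows that removing a pyridin-2-yl from that aromatic carbon left the number essentially unchanged. A pyridin-3-yl entering there is therefore expected to shift this assay by no more than the scatter, in no clear direction. Compound 4 is estimated at 18 nM, within a range from 8 nM to 40 nM. That corresponds to an expected 1.1-fold higher number from compound 2 to compound 4 (0.02 log units; within the scatter).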

Compound 4, inhibition constant: 61 nM
Beside the measured number, compound 4's estimate is 3.4-fold (0.53 log units) below it; measured number outside the range, above it.
By their numbers in this assay, from the lowest: compounds 2 and 1 (each within the scatter of the next); then compound 4; then compound 3.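

The aromatic carbon next to the ring oxygen is not indifferent to what it carries: in this assay, adding pyridin-3-yl gives a 3.6-fold higher number from compound 2 to compound 4 (0.55 log units; beyond the scatter), whereas pyridin-2-yl there stayed within the scatter of hydrogen. Exchanging pyridin-2-yl for pyridin-3-yl gives a 3.4-fold higher number from compound 1 to compound 4 (0.53 log units; beyond the scatter), so which pyridinyl group sits there matters, not just the presence of a ring. Nothing available explains this difference.

Still open, going by these compounds, is whether a pyridin-4-yl or plain phenyl group at this carbon would follow pyridin-2-yl or pyridin-3-yl. Also open, on these data alone, is how a carboxylic acid on the added ring would shift the number.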